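Notes on compound 3, one chain carbon longer than compound 2

The compounds below may be only part of what the source reports. "The series", "measured", "known", "first", "only" and "open" are said of these compounds alone.

Compound 1 `CCCCCN(Cc1ccc(C(=O)NO)cc1)c1ncc(-c2ccc(C)cc2)s1` gives 9140 nM in a functional assay on A549 cells (Homo sapiens) for antiproliferative activity, read by MTT assay, with a stated time of 48 h; on this read-out lower numbers stand for stronger inhibition of growth and higher numbers for weaker inhibition of growth. Among the measured compounds shown here, compound 2 `Cc1ccc(OCCCN(Cc2ccc(C(=O)NO)cc2)c2ncc(-c3ccc(C)cc3)s2)cc1` gives 32500 nM in this assay, the higher of the two numbers; the single measured step, a 3.6-fold higher number from compound 1 to compound 2 (0.55 log units; beyond the scatter), is the only comparison in hand. Compound 3 `Cc1ccc(OCCCCN(Cc2ccc(C(=O)NO)cc2)c2ncc(-c3ccc(C)cc3)s2)cc1` differs from compound 2 by (4-methylphenoxy)methyl in place of 4-methylphenoxy on a saturated chain carbon, three bonds along the chain from a nitrogen on an aromatic ring. For the measured compounds named here, no measured step alters chain length alone, and the step from compound 1 to compound 2 concerns a different exchange, so no step beyond the scatter is expected, a 1.1-fold lower number from compound 2 to compound 3 (0.03 log units; within the scatter). Compound 3 is estimated at 30000 nM, within 12000 nM to 80000 nM.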

Compound 3, concentration for 50% growth inhibition: 8630 nM
Estimate against measurement, compound 3: 3.5-fold (0.54 log units) above; the measured number lies below the stated range.
By their numbers in this assay, from the lowest: compounds 3 and 1 (each within the scatter of the next); then compound 2.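

Going from 3-(4-methylphenoxy)propyl to 4-(4-methylphenoxy)butyl gives a 3.8-fold lower number from compound 2 to compound 3 (0.58 log units; beyond the scatter) in this assay, so chain length alone moves the number at this position beyond the scatter. The cost of 4-methylphenoxy is therefore not general: at the longer chain, 4-methylphenoxy in place of methyl gives a 1.1-fold lower number from compound 1 to compound 3 (0.02 log units; within the scatter) in this assay, with no change beyond the scatter. No supporting measurement bears on why chain length matters here.

From the compounds shown here alone, whether a longer chain would lower the number further stays open, as does whether an amine or a carboxylic acid in place of 4-methylphenoxy at the chain end would keep it.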